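From 2-fluorophenyl to 4-(trifluoromethyl)phenyl on compound 1

This account rests on a few compounds, and the source may have more. Where it says the series, first, only, none or still open, it means among the compounds named here.

In a functional assay on GBM1 cells (Homo sapiens) for antiproliferative activity, read by WST assay, with a stated time of 72 h (on this read-out lower numbers stand for stronger inhibition and higher numbers for weaker inhibition), compound 1 `O=C(Nc1ccccc1F)Nc1cc2ncncc2cc1OCc1ccccc1` gives 6100 nM and compound 2 `O=C(Nc1ccccc1F)Nc1cc2ncncc2cc1OCc1ccccc1F` gives 4200 nM which leaves the two within the scatter of each other. Within the data shown here, compound 3 `O=C(Nc1ccc(C(F)(F)F)cc1)Nc1cc2ncncc2cc1OCc1ccccc1` keeps the core of compound 1 but carries 4-(trifluoromethyl)phenyl in place of 2-fluorophenyl on an amide-type nitrogen and no measured step touches that place. Among the measured compounds shown here, the one measured step of a 1.5-fold lower number from compound 1 to compound 2 (0.16 log units; within the scatter) is a fluoro in place of hydrogen on an aromatic carbon of another group, so it gives only weak guidance and no direction. The expected change is an estimated 1.4-fold lower number from compound 1 to compound 3 (0.13 log units; within the scatter) which would not go beyond the scatter. In this assay the estimate for compound 3 is 4500 nM (expected range 1300 nM to 15000 nM).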

Compound 3, half-maximal inhibitory concentration: 5700 nM
For compound 3 the middle estimate is 1.3-fold (0.10 log units) below the measured one, within the range that was stated.
By their numbers in this assay, from the lowest: compounds 2, 3 and 1 (each within the scatter of the next).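

In this assay, replacing 2-fluorophenyl with 4-(trifluoromethyl)phenyl on the amide-type nitrogen gives a 1.1-fold lower number from compound 1 to compound 3 (0.03 log units; within the scatter). Among these compounds, this is the first view of this position, and a group with more heavy atoms, carrying fluorine in a different arrangement, leaves the number within the scatter of compound 1. No supporting measurement explains this result. From the compounds shown here alone, whether an amine or a carboxylic acid on this phenyl ring would move the number beyond the scatter remains open. So does the effect of replacing the phenyl ring with a longer carbon chain.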